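The source may hold more compounds than are shown below. What is called first, only, known or untested is meant among the compounds shown, and "the series" means these compounds.

In a functional assay on KB cells (Homo sapiens) for cytotoxicity, read by MTT assay, with a stated time of 48 h (a higher number here means a weaker inhibitor, a lower number a stronger inhibitor), compound 1 `CCn1cc(-c2nc3ccccc3[nH]2)c(=O)c2cc(F)c(N3CCNC(C)C3)c(F)c21` gives 19100 nM, compound 2 `CCn1cc(-c2nc3ccccc3o2)c(=O)c2cc(F)c(Cl)cc21` gives 10200 nM and compound 3 `CCn1cc(-c2nc3ccccc3o2)c(=O)c2cc(F)c(N3CCNCC3)nc21` gives 11700 nM. Compound 3 thus stands within the scatter of both other compounds.

Compound 4 `CCn1cc(-c2nc3ccc(Cl)cc3[nH]2)c(=O)c2cc(F)c(N3CCNCC3)nc21` keeps the rest of compound 3 but carries 6-chloro-1H-benzimidazol-2-yl in place of 1,3-benzoxazol-2-yl, on an aromatic carbon of a six-membered aromatic ring with 1 nitrogen (6-chloro-1H-benzimidazol-2-yl in place of 1,3-benzoxazol-2-yl on an aromatic carbon).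

Within the data shown here, no pair of measured compounds differs in only one place, so the data offer no direct measure of this change. Among the measured compounds shown here, the three measured compounds nevertheless differ in their structures and remain within the scatter of one another, which is the only guide available. On that basis, no shift beyond the scatter is expected in this assay, in either direction.

The estimated step of a 1.1-fold higher number from compound 3 to compound 4 (0.05 log units; within the scatter) stays within the scatter.

Compound 4 is expected at 13000 nM, with an estimated range from 5500 nM to 30000 nM.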

Compound 4, half-maximal inhibitory concentration: 10300 nM
The estimate for compound 4 lay 1.3-fold (0.10 log units) above the measured number, within the range that was stated.
By their numbers in this assay, from the lowest: compounds 2, 4, 3 and 1 (each within the scatter of the next).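

In this assay, putting 6-chloro-1H-benzimidazol-2-yl in place of 1,3-benzoxazol-2-yl on this aromatic carbon gives a 1.1-fold lower number from compound 3 to compound 4 (0.06 log units; within the scatter), the first direct measure of a change at this position. The entering group carries a chlorine and a hydrogen-bond donor that the leaving group lacks, yet the step stays within the scatter, so this exchange has no readable effect in this assay. Nothing measured here accounts for that outcome.

The exchange alters the ring hetero atoms and adds the chlorine in a single step, and the compounds shown do not separate these two changes. From the compounds shown here alone, it remains open whether an unsubstituted 1H-benzimidazol-2-yl on this same core, or a carboxylic acid or an amine on this carbon, would shift the number beyond the scatter.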